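The source may report more compounds than this note shows. Statements on the series, on what has been measured and on what is new or still open speak of the compounds shown alone.

In an assay on isolated protein for inhibition of hexokinase-1 (Rattus norvegicus), with a stated time of 6 h, tested at 10 mM (a lower number here means less inhibition, a higher number more inhibition at the concentration tested (going by the name of the read-out)), the measured compounds gave:

Compound 1 `O=C(CI)NCCCCCC(=O)NCCCCCCNc1ncnc2c1ncn2[C@@H]1O[C@H](COP(=O)(O)OP(=O)(O)OP(=O)(O)O)[C@@H](O)[C@H]1O`: 0%
Compound 2 `O=C(CI)NCCCCC(=O)NCCCCCCNc1ncnc2c1ncn2[C@@H]1O[C@H](COP(=O)(O)OP(=O)(O)OP(=O)(O)O)[C@@H](O)[C@H]1O`: 0%
Compound 3 `CN(CCCN(C)C(=O)CCCCNc1ncnc2c1ncn2[C@@H]1O[C@H](COP(=O)(O)OP(=O)(O)OP(=O)(O)O)[C@@H](O)[C@H]1O)C(=O)CCCCNC(=O)CI`: 0%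

Compound 2 stands level with compounds 1 and 3 at the digits shown. Its nearest neighbour is compound 1 and its furthest is compound 3, and in both cases the difference lies within the scatter. Going by the values given here, the only measured step, no change at the digits printed from compound 1 to compound 2 (within the scatter), shortened the chain while keeping the iodine-bearing end in place, and it produced no change.

Compound 4 `CC(=O)NCCCCCCCCNc1ncnc2c1ncn2[C@@H]1O[C@H](COP(=O)(O)OP(=O)(O)OP(=O)(O)O)[C@@H](O)[C@H]1O` differs from compound 2 as follows: a group of 6 heavy atoms (4 carbon, 1 nitrogen, 1 oxygen; no ring) in place of a group of 12 heavy atoms (7 carbon, 2 nitrogen, 2 oxygen, 1 iodine; no ring), on a saturated chain carbon, six bonds along the chain from a nitrogen on an aromatic ring. Among the compounds with values here, no measured step removes the iodine-containing group, so that part of the change has no direct precedent. Within the data shown here, what the data do show is that all three measured compounds, each carrying that group, give no inhibition at all, and the one measured step bearing on this chain was flat. The expected step from compound 2 to compound 4 is therefore none beyond the scatter: no change at the digits printed from compound 2 to compound 4 (within the scatter). For compound 4 the estimate in this assay is 0%, with an expected range from -8% to 10%.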

Compound 4, a percentage reported as inhibition, at one concentration (the size of the read-out at that concentration, not a potency): 0%
For compound 4 middle estimate and measured number coincide at the digits printed, within the range that was stated.
By their numbers in this assay, from the lowest: compounds 1, 2, 3 and 4 (each within the scatter of the next).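

Compounds 1, 2 and 3 all carry the iodine-bearing end, so they could not show what happens without it. Replacing that group with 2-acetamidoethyl, on a saturated chain carbon, six bonds along the chain from a nitrogen on an aromatic ring, gives no change at the digits printed from compound 2 to compound 4 (within the scatter) in this assay, so the iodine-containing group makes no visible difference at this position. Since compound 4 reads 0%, level with the others, this is a comparison of compounds that all show no inhibition, and it cannot tell whether either group helps or harms; no supporting evidence on this result is available.

The compounds shown leave open whether any change at this chain end can produce measurable inhibition. An amine, a carboxylic acid or a longer chain in this place could test that.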